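Fluoro in Place of Hydrogen: Expecting Compound 3

The compounds below may be only part of what the source reports. "The series", "measured", "known", "first", "only" and "open" are said of these compounds alone.

Compound 2 `CC(=O)OC/C(=C\c1ccccc1)C(=O)c1ccccc1` gives 16000 nM in a functional assay on T47D cells (Homo sapiens) for inhibition, read by sulforhodamine B assay, with a stated time of 48 h; on this read-out higher numbers stand for weaker inhibition of growth and lower numbers for stronger inhibition of growth. Compound 1 `O=C(/C(=C/c1ccccc1)CCl)c1ccccc1` gives 18000 nM in this assay, and the step of a 1.1-fold lower number from compound 1 to compound 2 (0.05 log units; within the scatter) is within the scatter, so the two numbers sit side by side. Compound 3 `CC(=O)OC/C(=C\c1ccc(F)cc1)C(=O)c1ccccc1` differs from compound 2 by fluoro in place of hydrogen on an aromatic carbon. Going by the values given here, no measured step bears on this change; the one step known concerns the chain, not the ring. Compound 3 is therefore expected to stay near compound 2, with no change at the digits printed from compound 2 to compound 3 (within the scatter) not beyond the scatter. The estimate for compound 3 in this assay is 16000 nM, within a range from 7000 nM to 35000 nM.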

Compound 3, concentration for 50% growth inhibition: 14000 nM
Beside the measured number, compound 3's estimate is 1.1-fold (0.06 log units) above it; the range from low to high includes it.
By their numbers in this assay, from the lowest: compounds 3, 2 and 1 (each within the scatter of the next).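

In this assay, going by these compounds alone, the change from phenyl to 4-fluorophenyl gives a 1.1-fold lower number from compound 2 to compound 3 (0.06 log units; within the scatter) and is the first measured step on the ring rather than the chain. Fluoro on this aromatic carbon, para to a large group, thus leaves the number level with that of hydrogen. No evidence bearing on this result is at hand.

On these data alone, whether an amine, a methoxy group or a carboxylic acid on this same carbon would also leave the number in place stays open. So does the effect of chloro there.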